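A few compounds are considered here, and "the series" means these few. Any claim that something is new, unique, unknown or untested is made for them only; others in the source may bear on it.

Compound 1 `COc1ccc(-c2cnc(NC(=O)c3cccnc3)n2C)cc1` is tolerated up to the ceiling of a toxicity assay on THP-1 cells (Homo sapiens) for inhibition; a lower number here means that less compound is tolerated, a higher number that more compound is tolerated: its value there, > 100000 nM, is a limit of the assay and not a number. Compound 2 `Cc1ccccc1-c1cnc(NC(=O)c2ccc(F)cc2)n1C` likewise gives only a limit in this assay, > 50000 nM. Within the shared core, compound 1 stands at the limit of > 100000 nM in this assay, at which 1 of the 2 values shown sits. Compound 3 `COc1ccc(-c2cnc(NC(=O)c3ccccc3F)n2C)cc1` has not been measured. It differs from compound 1 in one place: 2-fluorophenyl in place of pyridin-3-yl on a carbonyl carbon. Among the compounds with values here, no measured step exists, so no shift beyond the scatter is expected; the expected step is a number no higher from compound 1 to compound 3 (the limit leaves the size open). Compound 3 is expected to give 100000 nM in this assay, within 50000 nM to 200000 nM, most likely again as a limit.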

Compound 3, half-maximal cytotoxic concentration: > 100000 nM
Compound 3: a limit, no number; the forecaster's own chance of this, stated with the estimate: 70%; the middle value sits exactly at the limit.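

Compound 1 and compound 3 both give only a limit in this assay, so no step between them can be read: the limit of > 100000 nM in this assay, at which 2 of the 3 values shown sit.

The compounds shown leave open whether 2-fluorophenyl in place of pyridin-3-yl changes the tolerated concentration at all.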